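This account rests on a few compounds, and the source may have more. Where it says the series, first, only, none or still open, it means among the compounds named here.

Measured so far in a functional assay on HOS-TE85 cells (Homo sapiens) for inhibition, read by CCK-8 assay, with a stated time of 72 h; on this read-out higher numbers stand for weaker inhibition and lower numbers for stronger inhibition:
- compound 1 `COc1ccc(F)cc1N1C(=O)CSC1c1cccc(C(=O)NCCCCc2ccccc2)c1` gives 8.8 nM
- compound 2 `COc1ccccc1N1C(=O)CSC1c1cccc(C(=O)NCCCCN2CCN(C(=O)OC(C)(C)C)CC2)c1` gives > 1000 nM, which is a limit of this assay and not a number
- compound 3 `O=C(NCCCCn1cccn1)c1cccc(C2SCC(=O)N2c2cc(F)ccn2)c1` gives 33.2 nM

Among the two numbers shown, compound 1 stands lowest; compound 3 gives a higher number, and that gap is beyond the usual scatter. Compound 2 returns only a limit. Compound 4 `O=C(NCCCCc1ccccc1)c1cccc(C2SCC(=O)N2c2ccc(C3CC3)cc2)c1` keeps the shared core and the amide-type tail of compound 1 and alters the substituent on the ring nitrogen: 4-cyclopropylphenyl in place of 5-fluoro-2-methoxyphenyl on an amide-type nitrogen in a ring. Within the data shown here, no step between measured compounds isolates this change. The step from compound 1 to compound 4 is expected to be a modest rise in number, probably beyond the scatter: a 2.8-fold higher number from compound 1 to compound 4 (0.45 log units; beyond the scatter). For compound 4 the estimate in this assay is 25 nM, with a likely range from 6 nM to 120 nM.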

Compound 4, half-maximal inhibitory concentration in the HOS-TE85 assay: 217 nM
For compound 4 the middle estimate is 8.7-fold (0.94 log units) below the measured one; the whole stated range lies below it.
By their numbers in the HOS-TE85 assay, from the lowest: compound 1; then compound 3; then compound 4. At a limit, above all of these: compound 2.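

In the HOS-TE85 assay, the substituent on the amide-type nitrogen in the ring proves a sensitive place: 4-cyclopropylphenyl in place of 5-fluoro-2-methoxyphenyl gives a 25-fold higher number from compound 1 to compound 4 (1.39 log units; beyond the scatter), the only step shown that isolates this position. In a physicochemical assay for solubility, read by turbidimetry, measured as kinetic solubility, at pH 6.8 (a higher number here means a more soluble compound, a lower number a less soluble compound), compound 1 gives 10000 nM and compound 4 gives 2000 nM. The same change also lowers the number in the physicochemical assay: the measured solubility of compound 1, 10000 nM, and of compound 4, 2000 nM, a 5.0-fold lower number (0.70 log units; beyond the scatter)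

As far as these compounds go, this single step removes the methoxy and the fluorine and adds the cyclopropyl together, so the share of each in the rise remains open. Also open, from the compounds shown here alone, is how a phenyl ring carrying a dimethylamino group or a carboxylic acid would fare at this position in both read-outs.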